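A Nitro Group Replaces Methyl on the Aryl Hydrazone

The source may hold more compounds than are shown below. What is called first, only, known or untested is meant among the compounds shown, and "the series" means these compounds.

Compound 3 `Cc1ccccc1N/N=C1\CCC(C)n2c1ncc(C(=O)O)c2=O` was tested in a functional assay on the whole organism for inhibition, with Rattus norvegicus as the target; on this read-out higher numbers stand for an effect only at larger amounts of compound and lower numbers for an effect already at smaller amounts. In this assay compound 3 gives only a limit, > 100 umol/kg, and no number. Its two relatives are in the same position. Compound 1 `CC1CC/C(=N\Nc2ccccc2Br)c2ncc(C(=O)O)c(=O)n21` reaches only the limit > 320 umol/kg in this assay. Compound 2 `COc1ccccc1N/N=C1\CCC(C)n2c1ncc(C(=O)O)c2=O` likewise stops at the limit > 1000 umol/kg. Because all three values are limits, as the limit of > 100 umol/kg in this assay, at which 1 of the 3 values shown sits, the limit of > 320 umol/kg in this assay, at which 1 of the 3 values shown sits, and the limit of > 1000 umol/kg in this assay, at which 1 of the 3 values shown sits, show, no size can be read for any of the measured steps: a step that the two limits leave unreadable from compound 1 to compound 3 and a step that the two limits leave unreadable from compound 2 to compound 3 are both unreadable, as is a step that the two limits leave unreadable from compound 1 to compound 2. Compound 3 therefore stands at a limit among compounds that all stand at limits, and no order among them can be stated.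

Compound 4 `CC1CC/C(=N\Nc2ccccc2[N+](=O)[O-])c2ncc(C(=O)O)c(=O)n21` differs from compound 3 by a single change: nitro in place of methyl on an aromatic carbon. Among the compounds with values here, the steps that bear on it, from compound 1 and from compound 2 to compound 3, tell nothing of size, so no step beyond the scatter can be expected in either direction. Compound 4 is therefore expected to give 300 umol/kg in this assay, with a range from 60 umol/kg to 1500 umol/kg. This expectation amounts to an estimated step that the limit leaves unreadable from compound 3 to compound 4.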

Compound 4, dose for 50% inhibition: > 1000 umol/kg
Compound 4: only a limit was reported; the forecaster's own chance of this, stated with the estimate: 70%; middle value at least 3.3-fold (0.52 log units) away from the limit.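

In this assay compound 4 gives only a limit, > 1000 umol/kg. Within the data shown here, no step from compound 1, compound 2 or compound 3 to compound 4 can be read. The compounds shown leave open what dose of any of these four gives half inhibition in this assay, and whether exchanging the aromatic group changes it.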